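The source may hold more compounds than are shown below. What is called first, only, known or untested is meant among the compounds shown, and "the series" means these compounds.

In a functional assay on EOL1 cells (Homo sapiens) for inhibition, read by fluorescence, with a stated time of 72 h (a higher number here means a weaker inhibitor of growth, a lower number a stronger inhibitor of growth), compound 1 `N[C@H]1CC[C@H](Nc2nc(Nc3ccc(Cl)cc3)c3ncn(C4CCCCC4)c3n2)CC1` gives 140 nM, compound 2 `CC(C)=CCn1cnc2c(Nc3cccc(Cl)c3)nc(N[C@H]3CC[C@H](N)CC3)nc21` gives 80 nM and compound 3 `CCCCCCn1cnc2c(Nc3cc(OC)cc(OC)c3)nc(N[C@H]3CC[C@H](N)CC3)nc21` gives 380 nM. The numbers for compound 2 and compound 1 lie within the usual scatter of each other, so these two cannot be ranked. Compound 3 has a number clearly higher than that of compound 2, which marks it as the weaker inhibitor of growth of that pair.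

Compound 4 `CC(C)CCn1cnc2c(Nc3cccc(Cl)c3)nc(N[C@H]3CC[C@H](N)CC3)nc21` has not been measured yet. It differs from compound 2 in one place: isobutyl in place of 2-methylprop-1-en-1-yl on a saturated chain carbon bound to an aromatic nitrogen. In words, isobutyl stands in place of 2-methylprop-1-en-1-yl on a saturated chain carbon bound to an aromatic nitrogen, so the double bond outside aromatic rings is lost while the heavy-atom count stays the same.

Within the data shown here, no measured pair shows this change on its own. Starting from compound 2 at 80 nM, no step beyond the scatter is expected in this assay, in either direction. The estimated 1.3-fold higher number from compound 2 to compound 4 (0.10 log units; within the scatter) is therefore small. For compound 4 the expected value is 100 nM, with an estimated range from 40 nM to 250 nM.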

Compound 4, concentration for 50% growth inhibition: 60 nM
Compound 4: the middle estimate sits 1.7-fold (0.22 log units) above what was measured; measured number inside the range.
By their numbers in this assay, from the lowest: compounds 4, 2 and 1 (each within the scatter of the next, the first and the last beyond it); then compound 3.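

Among these compounds, compound 2 and compound 4 form the first pair here that differs in one place only, and in this assay the step reads a 1.3-fold lower number from compound 2 to compound 4 (0.12 log units; within the scatter) and so stays small. On a saturated chain carbon bound to an aromatic nitrogen, then, the double bond outside aromatic rings can be lost, with the heavy-atom count unchanged, without any change in growth inhibition that can be told from the scatter. Nothing at hand accounts for the two side chains reading alike.

The compounds shown leave open how this position responds to a chain that carries an amine or a carboxylic acid, or to a longer branched chain. They also leave open whether 3-methylbut-2-en-1-yl and isopentyl would still read alike on a core that differs elsewhere.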